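Bromo on the pendant phenyl in two sulfonyl-urea cores

This account rests on a few compounds, and the source may have more. Where it says the series, first, only, none or still open, it means among the compounds named here.

Measured so far:
compound 1 `O=C1NC(c2ccc(Br)cc2)CN1S(=O)(=O)c1ccc2c(c1)CCC2`, 32600 nM
compound 2 `Cc1ccc(S(=O)(=O)N2C(=O)NCC2c2ccccc2)cc1`, > 316000 nM
compound 3 `O=C1NC(c2ccccc2)CN1S(=O)(=O)c1ccc2c(c1)CCC2`, 2 nM

In a functional assay on SK-MEL-2 cells (Homo sapiens) for cytotoxicity (on this read-out lower numbers stand for stronger inhibition and higher numbers for weaker inhibition), compound 3 gives 2 nM. Compound 1 carries the change bromo in place of hydrogen on an aromatic carbon and gives 32600 nM in this assay; the step is a 16000-fold higher number from compound 3 to compound 1 (4.21 log units; beyond the scatter). For compound 2 the value in this assay is only a limit, > 316000 nM, which is the limit of > 316000 nM in this assay, at which 1 of the 3 values shown sits. The difference between the core of compound 2 and the core of compound 3 is not broken down here.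

Compound 4 `Cc1ccc(S(=O)(=O)N2C(=O)NCC2c2ccc(Br)cc2)cc1` is not yet measured. It differs from compound 2 by bromo in place of hydrogen on an aromatic carbon, the same kind of change as from compound 3 to compound 1, with the same place description in both cases.

For the measured compounds named here, since the one measured instance of this change is the large step of a 16000-fold higher number from compound 3 to compound 1 (4.21 log units; beyond the scatter), and compound 2 already sits at the limit, compound 4 is expected to stay at or beyond that limit in this assay, an estimated step that the limit leaves unreadable from compound 2 to compound 4. The estimate for compound 4 is 500000 nM, expected between 316000 nM and 3000000 nM.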

Compound 4, half-maximal inhibitory concentration: 80000 nM
Compound 4: middle estimate off by 6.3-fold (0.80 log units), on the high side, and the stated range ends above it.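

In this assay, phenyl to 4-bromophenyl gives an at least 3.9-fold lower number from compound 2 to compound 4 (0.59 log units; beyond the scatter). The same change therefore does not carry over from one core to the other, in either direction or size: the same change on two cores in this assay, a 16000-fold higher number (4.21 log units; beyond the scatter) from compound 3 to compound 1 and an at least 3.9-fold lower number (0.59 log units; beyond the scatter) from compound 2 to compound 4, at least 64000-fold (4.80 log units) apart, beyond the scatter of two such steps The value of compound 2, > 316000 nM, is a limit, so the new step is only bounded, and two pairs show neither a cause for the gap nor how the change would behave on any further core.

Still open, from the compounds shown here alone, is whether the opposite outcomes belong to bromo itself or would recur with another group in its place on the phenyl ring, such as chloro, methoxy or an amine, carried on both cores. Also open, going by these compounds, is whether a third sulfonyl substituent, for example one ending in a carboxylic acid, would follow the pair of compound 3 and compound 1 or the pair of compound 2 and compound 4.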